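A few compounds are considered here, and "the series" means these few. Any claim that something is new, unique, unknown or untested is made for them only; others in the source may bear on it.

Of the compounds shown here, three that share one core have been tested in a functional assay on HL-60 cells (Homo sapiens) for antiproliferative activity, read by MTT assay, with a stated time of 48 h; a higher number here means a weaker inhibitor, a lower number a stronger inhibitor: compound 1 `Cn1c(N)c(-c2nc3ccccc3[nH]2)c2nc(C#N)c(C#N)nc21`, compound 2 `CN(C)CCn1c(N)c(-c2nc3ccccc3[nH]2)c2nc(C#N)c(C#N)nc21` and compound 3 `N#Cc1nc2c(-c3nc4ccccc4[nH]3)c(N)n(CCO)c2nc1C#N`. Compound 3 gives > 50000 nM, which is a limit and not a number. Compound 1 gives > 50000 nM, also a limit. Together they make up (the limit of > 50000 nM in this assay, at which 2 of the 3 values shown sit). Among the compounds with values here, compound 2 gives 2220 nM, the only true number of the three.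

The next compound, compound 4 `CN1CCN(CCCn2c(N)c(-c3nc4ccccc4[nH]3)c3nc(C#N)c(C#N)nc32)CC1`, departs from compound 3 by (4-methylpiperazin-1-yl)methyl in place of hydroxy on a saturated chain carbon, two bonds along the chain from an aromatic nitrogen. In words, (4-methylpiperazin-1-yl)methyl stands in place of hydroxy on a saturated chain carbon, two bonds along the chain from an aromatic nitrogen, so that 2-hydroxyethyl becomes 3-(4-methylpiperazin-1-yl)propyl.

The closest guide is an at least 22-fold higher number from compound 2 to compound 3 (1.35 log units; beyond the scatter), a large step in which hydroxy replaced dimethylamino at that same place; the new change runs the opposite way, from hydroxy to an amine-bearing group. Also large is an at least 22-fold lower number from compound 1 to compound 2 (1.35 log units; beyond the scatter), where (dimethylamino)methyl was added. By contrast, a step that the two limits leave unreadable from compound 1 to compound 3 cannot be read. The expectation rests on compound 2 alone, and its group differs from the new one, so the range stays wide.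

A large fall in the number is expected, given as an at least 20-fold lower number from compound 3 to compound 4 (1.30 log units; beyond the scatter). The estimate for compound 4 is 2500 nM, with an expected range from 500 nM to 15000 nM.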

Compound 4, half-maximal inhibitory concentration: 750 nM
Compound 4: the middle estimate sits 3.3-fold (0.52 log units) above what was measured, within the range that was stated.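

In this assay, a second amine-bearing group at this place, on a saturated chain carbon, two bonds along the chain from an aromatic nitrogen, also stands well clear of the hydroxy compound, so the large step seen with compound 2 no longer rests on dimethylamino alone: the change gives an at least 66-fold lower number from compound 3 to compound 4 (1.82 log units; beyond the scatter), and the full 2-(4-methylpiperazin-1-yl)ethyl addition gives an at least 66-fold lower number from compound 1 to compound 4 (1.82 log units; beyond the scatter). Both steps start from a limit and not from a number, so they give only a lower bound on the size of the change: the limit of > 50000 nM in this assay, at which 2 of the 4 values shown sit.

Within the data shown here, the only step here between two true numbers is much smaller, a 3.0-fold lower number from compound 2 to compound 4 (0.47 log units; beyond the scatter), and it shows that the choice among the two amine-bearing groups still moves the result beyond the scatter, though far less than the step away from hydroxy.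

The 3-(4-methylpiperazin-1-yl)propyl group of compound 4 differs from the group of compound 2 in both its amine and its chain, and the compounds shown do not separate these two parts. A 3-(dimethylamino)propyl or a 2-(4-methylpiperazin-1-yl)ethyl group would bear on that, while a morpholine or a carboxylic acid at the chain end would test whether an amine is needed at all.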